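This account rests on a few compounds, and the source may have more. Where it says the series, first, only, none or still open, it means among the compounds named here.

Measured compounds in an ADME assay on HEK293 cells (Homo sapiens) for cytotoxicity, read by resazurin assay, with a stated time of 48 h; a lower number here means that less compound is tolerated, a higher number that more compound is tolerated:

Compound 1, `O=S(=O)(Nc1ccc(-c2nc3ccccc3o2)cc1)c1ccc(Cl)s1`, gives in this assay a limit of the assay, > 100000 nM.
Compound 2, `C=Cc1ccc(S(=O)(=O)Nc2ccc(-c3nc4ccccc4o3)cc2)cc1`, gives in this assay a limit of the assay, > 100000 nM.
Compound 3, `COc1ccccc1S(=O)(=O)Nc1ccc(-c2nc3ccccc3o2)cc1`, gives in this assay a limit of the assay, > 100000 nM.

Compound 3 therefore stands at the ceiling of what was measured, with nothing to set it apart from the other two: all three sit at the limit of > 100000 nM in this assay, at which 3 of the 3 values shown sit. The step to the unmeasured compound 4, `O=S(=O)(Nc1ccc(-c2nc3ccccc3o2)cc1)c1cccc(F)c1`, changes the group on the sulfonyl sulfur: 3-fluorophenyl in place of 2-methoxyphenyl on a sulfonyl sulfur.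

Among the compounds with values here, two measured steps touch the same position and so bear on this change. The step that the two limits leave unreadable from compound 1 to compound 3 and the step that the two limits leave unreadable from compound 2 to compound 3 each exchange the group on the sulfonyl sulfur, yet neither has a readable size, since both ends of each sit at the limit. Nothing in these data shows any exchange at this position moving a compound away from the limit, and no step beyond the scatter is expected for this assay in either direction.

Compound 4 is therefore expected to tolerate compound much like compound 3, with an estimate of 150000 nM and a range from 50000 nM to 500000 nM, most likely reported again only as a limit; the expected step is a step that the limit leaves unreadable from compound 3 to compound 4.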

Compound 4, half-maximal cytotoxic concentration: > 100000 nM
Compound 4 was reported as a limit; the forecaster's own chance of this, stated with the estimate: 85%; the middle value does not contradict the limit.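

Compound 4 gives > 100000 nM in this assay, which is a limit of the assay. Its steps from compound 1, compound 2 and compound 3 cannot be read, since all four compounds share one limit: the limit of > 100000 nM in this assay, at which 4 of the 4 values shown sit. The compounds shown leave open whether any group on the sulfonyl sulfur would give a readable value.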